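A few compounds are considered here, and "the series" means these few. Any claim that something is new, unique, unknown or untested is made for them only; others in the source may bear on it.

Measured compounds:
compound 1, `Cc1ccc(S(=O)(=O)/C(=C/c2ccc(C)s2)C(=O)c2ccc(Br)cc2)cc1`, 25000 nM
compound 2, `CCOc1cc(/C=C(\C(=O)c2ccc(Cl)cc2)S(=O)(=O)Cc2ccc(Cl)cc2)ccc1O`, 10000 nM
compound 3, `O=C(/C(=C\c1ccc(Br)c([N+](=O)[O-])c1)S(=O)(=O)c1ccc(Br)cc1)c1ccc(Br)cc1`, 10000 nM

In a functional assay on DU-145 cells (Homo sapiens) for inhibition, read by trypan blue exclusion, with a stated time of 96 h (a lower number here means a stronger inhibitor of growth, a higher number a weaker inhibitor of growth), compound 2 gives 10000 nM, level at the digits shown with compound 3, which gives 10000 nM; together these two are the lowest of the three numbers, and the two sit within the scatter of each other, so no order between them can be read. The furthest is compound 1, which gives 25000 nM, a gap beyond the scatter.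

Compound 4, `Cc1ccc(/C=C(\C(=O)c2ccc(Cl)cc2)S(=O)(=O)Cc2ccc(Cl)cc2)s1`, has not been measured in this assay. It differs from compound 2 in one place: 5-methylthiophen-2-yl in place of 3-ethoxy-4-hydroxyphenyl on a double-bonded chain carbon bound to a double-bonded chain carbon. For the measured compounds named here, no step between measured compounds carries this same change, so the expectation rests on the bare numbers. Compound 1 also bears a 5-methylthiophen-2-yl group and gives the highest of the three numbers, but the rest of its structure differs from compound 2 in more than one place, so that comparison only loosely guides the estimate. A small step toward a weaker inhibitor, close to the edge of the scatter, is expected, as a 1.5-fold higher number from compound 2 to compound 4 (0.18 log units; within the scatter). Compound 4 is therefore estimated at 15000 nM, with a range from 6000 nM to 40000 nM.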

Compound 4, concentration for 50% growth inhibition: 1000 nM
For compound 4 the middle estimate is 15-fold (1.18 log units) above the measured one, and the stated range ends above it.
By their numbers in this assay, from the lowest: compound 4; then compounds 2 and 3 (each within the scatter of the next); then compound 1.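

For the compounds shown here, this is the first step that changes one place only: in this assay, 5-methylthiophen-2-yl in place of 3-ethoxy-4-hydroxyphenyl gives a 10-fold lower number from compound 2 to compound 4 (1.00 log units; beyond the scatter). It shows that the group on a double-bonded chain carbon bound to a double-bonded chain carbon has a strong bearing on growth inhibition, and that the 3-ethoxy-4-hydroxyphenyl group is not needed for it with this core. Nothing shown accounts for the size of this step.

The compounds shown leave open which part of the change carries the step, the thiophene ring, its methyl or the loss of the ethoxy and hydroxy groups; a plain thiophen-2-yl or a 4-hydroxyphenyl at this place would separate these. As far as these compounds go, the change is also seen in this single pair, so whether it holds with another core remains unknown.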